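Swapping the aryl amine substituent on compound 2

The source may hold more compounds than are shown below. What is called first, only, known or untested is meant among the compounds shown, and "the series" means these compounds.

The three measured compounds share one core and sit at the same point in a physicochemical assay for lipophilicity; on this read-out higher numbers stand for higher lipophilicity and lower numbers for lower lipophilicity. Compound 1 `NS(=O)(=O)Oc1ccc2c(c1)CN(C(=O)c1ccc(N3CCC(N4CCCCC4)CC3)cc1)CC2` gives 1.93, compound 2 `CCN(Cc1ccccn1)c1ccc(C(=O)N2CCc3ccc(OS(N)(=O)=O)cc3C2)cc1` gives 1.93, and compound 3 `NS(=O)(=O)Oc1ccc2c(c1)CN(C(=O)c1ccc(N(CCCO)Cc3ccccc3)cc1)CC2` gives 1.93; at the digits shown compound 2 is level with both, and none of these gaps exceeds the scatter. Compound 4 `CN(CCCN1CCCCC1)c1ccc(C(=O)N2CCc3ccc(OS(N)(=O)=O)cc3C2)cc1` has not been measured in this assay. It differs from compound 2 in one place: methyl(3-(piperidin-1-yl)propyl)amino in place of ethyl((pyridin-2-yl)methyl)amino on an aromatic carbon. Going by the values given here, no step between two measured compounds matches this change, so any expectation rests on the three values alone, and compound 1 at 1.93 shows that a piperidine-bearing substituent did not move the read-out. A step of a number 0.08 log units lower from compound 2 to compound 4 (within the scatter) is therefore expected, small and within the scatter. Compound 4 is estimated at 1.85, between 1.25 and 2.45.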

Compound 4, partition coefficient: 1.93
Compound 4: middle estimate off by 0.08 log units, on the low side; low and high end bracket the measured number.
By their numbers in this assay, from the lowest: compounds 1, 2, 3 and 4 (each within the scatter of the next).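

In this assay, methyl(3-(piperidin-1-yl)propyl)amino in place of ethyl((pyridin-2-yl)methyl)amino on an aromatic carbon gives no change at the digits printed from compound 2 to compound 4 (within the scatter) at this position. This single-place comparison shows that a six-membered aromatic ring with 1 hetero atom can give way to a six-membered non-aromatic ring with 1 hetero atom without a step beyond the scatter. The compounds shown leave open whether a carboxylic acid or a morpholine-bearing chain in this place would also stay level. No measurement shown accounts for this result.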